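Compound 3 to compound 4: furan-3-yl replaces 3-acetamidophenyl

A few compounds are considered here, and "the series" means these few. Any claim that something is new, unique, unknown or untested is made for them only; others in the source may bear on it.

Compound 1 `CC(=O)Nc1cccc(-c2ccc(C(=O)N(Cc3cccc(OCCCCCC(=O)O)c3)C(C)C)cc2)c1`: > 26000 nM
Compound 2 `Cc1nnc(-c2cccc(-c3ccc(C(=O)N(Cc4cccc(OCCCCCC(=O)O)c4)C(C)C)cc3)c2)o1`: > 26000 nM
Compound 3 `CCOC(=O)CCCCCOc1cccc(CN(C(=O)c2ccc(-c3cccc(NC(C)=O)c3)cc2)C(C)C)c1`: > 26000 nM

All three entries come from an ADME assay on HEK293 cells (Homo sapiens) for cytotoxicity, read by CellTiter-Glo and resazurin assay, with a stated time of 72 h (on this read-out lower numbers stand for an effect already at smaller amounts and higher numbers for an effect only at larger amounts of compound), and each is a limit, not a number. Compound 3 therefore has no exact value, only the limit > 26000 nM. It shares (the limit of > 26000 nM in this assay, at which 3 of the 3 values shown sit), so no order among the three compounds can be read.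

The next structure is compound 4 `CCOC(=O)CCCCCOc1cccc(CN(C(=O)c2ccc(-c3ccoc3)cc2)C(C)C)c1`. The change is furan-3-yl in place of 3-acetamidophenyl on an aromatic carbon, para to a large group.

For the measured compounds named here, two measured steps bear on this. One is a step that the two limits leave unreadable from compound 1 to compound 2, which also alters the group carried on an aromatic carbon, though it swaps acetamido rather than the whole 3-acetamidophenyl. The other is a step that the two limits leave unreadable from compound 1 to compound 3, which concerns a different part of the molecule. Neither has a readable size, so neither gives a direction, and the change to compound 4 is larger than the one in the first of these steps. No step beyond the scatter can be argued from these data. The estimated move is a step that the limit leaves unreadable from compound 3 to compound 4. A bare limit is again the likeliest report from this assay. For compound 4 the expected value is 28000 nM, with an estimated range from 10000 nM to 60000 nM.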

Compound 4, half-maximal effective concentration: > 26000 nM
Compound 4 gave a limit, no number (the forecaster's own chance of this, stated with the estimate: 80%); the middle value lies beyond the limit too.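

In this assay compound 4 gives > 26000 nM, which is a limit and not a number. Compound 3 is also reported only as a limit, so no step between compound 3 and compound 4 can be read: the limit of > 26000 nM in this assay, at which 4 of the 4 values shown sit.

The compounds shown leave open at what concentration, if any, each one affects these cells.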